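Swapping the pyridine attachment point in a dihydropyridine agonist

A few compounds are considered here, and "the series" means these few. Any claim that something is new, unique, unknown or untested is made for them only; others in the source may bear on it.

For the measured compounds named here, compound 2 `COCCO/C(O)=C1\C(C)=NC(C)=C([N+](=O)[O-])C1c1ccncc1` gives 37700 nM in a functional assay (cardiac atrium) for agonist activity, with Cavia porcellus as the target (on this read-out higher numbers stand for an effect only at larger amounts of compound and lower numbers for an effect already at smaller amounts), the higher of the two numbers known, since compound 1 `CC1=NC(C)=C([N+](=O)[O-])C(c2cccnc2)/C1=C(\O)OC1CCCCC1` gives 2760 nM. Compound 3 `COCCO/C(O)=C1\C(C)=NC(C)=C([N+](=O)[O-])C1c1cccnc1` differs from compound 2 by pyridin-3-yl in place of pyridin-4-yl on a saturated ring carbon. Going by the values given here, no pair measured here isolates that change, so its effect is not known; compound 1, which also carries pyridin-3-yl, only hints at a lower number. A modest step downward is expected, a 3.1-fold lower number from compound 2 to compound 3 (0.50 log units; beyond the scatter), with wide uncertainty. Compound 3 is estimated at 12000 nM, between 3000 nM and 40000 nM.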

Compound 3, half-maximal effective concentration: 49400 nM
Compound 3: middle estimate off by 4.1-fold (0.61 log units), on the low side; the whole stated range lies below it.
By their numbers in this assay, from the lowest: compound 1; then compounds 2 and 3 (each within the scatter of the next).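

The pyridine attachment point turns out to matter little here: pyridin-3-yl in place of pyridin-4-yl on the saturated ring carbon gives a 1.3-fold higher number from compound 2 to compound 3 (0.12 log units; within the scatter), so the two cannot be told apart. The large gap instead follows the group on the oxygen, where 2-methoxyethyl in place of cyclohexyl gives an 18-fold higher number from compound 1 to compound 3 (1.25 log units; beyond the scatter). Nothing available explains either step.

On these data alone, it remains open whether pyridin-2-yl or a phenyl ring on the saturated ring carbon would fit the same picture. As far as these compounds go, it is also open how an ethyl or benzyl group on the oxygen would compare with cyclohexyl.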